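The source may hold more compounds than are shown below. What is called first, only, known or untested is meant among the compounds shown, and "the series" means these compounds.

Compound 1 `CCCCc1oc2ccccc2c1C(=O)c1ccc(OCC(=O)N2CCCC2)cc1` is one of three measured compounds sharing a core; in a functional assay on MCF7 cells (Homo sapiens) for antiproliferative activity, read by MTT assay, with a stated time of 24 h (a lower number here means a stronger inhibitor, a higher number a weaker inhibitor), compound 1 gives 42400 nM. Compound 2 `CCCCc1oc2ccccc2c1C(=O)c1ccc(OCC(=O)N2CCOCC2)cc1` gives 34000 nM and compound 3 `CCCCc1oc2ccccc2c1C(=O)c1ccc(OCC(=O)Nc2cccc(OC)c2)cc1` gives 38500 nM, so the number for compound 1 is the highest of the three, yet every step among them stays within the scatter: a 1.2-fold lower number from compound 1 to compound 2 (0.10 log units; within the scatter) and a 1.1-fold lower number from compound 1 to compound 3 (0.04 log units; within the scatter). Compound 4 `CCCCNC(=O)CCCOc1ccc(C(=O)c2c(CCCC)oc3ccccc23)cc1` differs from compound 1 at the same end of the molecule: 2-(butylcarbamoyl)ethyl in place of (pyrrolidin-1-yl)carbonyl on a saturated chain carbon bound to an oxygen on an aromatic ring. The two measured steps bear on this change, and both were flat, so no step beyond the scatter is expected in this assay. Compound 4 is therefore estimated at 40000 nM, with a range from 15000 nM to 100000 nM, meaning an expected 1.1-fold lower number from compound 1 to compound 4 (0.03 log units; within the scatter).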

Compound 4, half-maximal inhibitory concentration: > 50000 nM
Compound 4: a limit, no number; the forecaster's own chance of this, stated with the estimate: 10%; at least 1.2-fold (0.09 log units) between middle value and limit.
By their numbers in this assay, from the lowest: compounds 2, 3 and 1 (each within the scatter of the next). At a limit, above all of these: compound 4.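

In this assay compound 4 gives a limit and not a number, > 50000 nM. The change to 2-(butylcarbamoyl)ethyl gives an at least 1.1-fold higher number from compound 1 to compound 4 (0.07 log units; that floor lies within the scatter), alongside an at least 1.2-fold higher number from compound 3 to compound 4 (0.11 log units; that floor lies within the scatter) and an at least 1.4-fold higher number from compound 2 to compound 4 (0.16 log units; that floor lies within the scatter). Each of these floors lies within the scatter, so this open-chain amide shows no real loss and rules none out, and its true step stays unknown: the limit of > 50000 nM in this assay, at which 1 of the 4 values shown sits.

The longer chain and the butyl amide change together here, so their shares cannot be separated. From the compounds shown here alone, whether a carboxylic acid or a tertiary amine at this end would give a clearly different number remains open.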